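Nitrogen substituent changes on the shared core

The source may hold more compounds than are shown below. What is called first, only, known or untested is meant among the compounds shown, and "the series" means these compounds.

For the measured compounds named here, compound 3 `CC(C(=O)NCc1ccc(C(F)(F)F)nc1N(C)C)c1ccc(NS(C)(=O)=O)c(F)c1` gives 19.1 nM in a functional assay on CHO-K1 cells for antagonist activity at transient receptor potential cation channel subfamily V member 1 (Homo sapiens), read by FLIPR (on this read-out lower numbers stand for stronger inhibition and higher numbers for weaker inhibition), the highest of the three numbers measured so far, though within the scatter of both neighbours: compound 2 `CC(C(=O)NCc1ccc(C(F)(F)F)nc1NCc1ccccc1)c1ccc(NS(C)(=O)=O)c(F)c1` gives 15.8 nM and compound 1 `Cc1ccc(Cl)cc1Nc1nc(C(F)(F)F)ccc1CNC(=O)C(C)c1ccc(NS(C)(=O)=O)c(F)c1` gives 14 nM. Compound 4 `CC(C(=O)NCc1ccc(C(F)(F)F)nc1N(C)c1ccccc1)c1ccc(NS(C)(=O)=O)c(F)c1` carries phenyl in place of methyl on a nitrogen on an aromatic ring. Going by the values given here, the steps that bear on this position are a 1.2-fold higher number from compound 2 to compound 3 (0.08 log units; within the scatter) and a 1.4-fold higher number from compound 1 to compound 3 (0.13 log units; within the scatter), with a 1.1-fold higher number from compound 1 to compound 2 (0.05 log units; within the scatter) between the two aromatic substituents; each of them falls within the scatter, so changes at this nitrogen have so far left this assay flat. On that basis the expected step of a 1.1-fold lower number from compound 3 to compound 4 (0.05 log units; within the scatter) is none beyond the scatter. Compound 4 is therefore estimated at 17 nM, with a range of 7 nM to 40 nM.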

Compound 4, inhibition constant: 0.9 nM
Compound 4: the middle estimate sits 19-fold (1.28 log units) above what was measured; measured number outside the range, below it.
By their numbers in this assay, from the lowest: compound 4; then compounds 1, 2 and 3 (each within the scatter of the next).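

In this assay, for the compounds shown here, this nitrogen is not flat after all: phenyl in place of methyl gives a 21-fold lower number from compound 3 to compound 4 (1.33 log units; beyond the scatter), the first step beyond the scatter. The aromatic ring alone does not account for it, since methyl(phenyl)amino also gives an 18-fold lower number from compound 2 to compound 4 (1.24 log units; beyond the scatter) against benzylamino and a 16-fold lower number from compound 1 to compound 4 (1.19 log units; beyond the scatter) against (5-chloro-2-methylphenyl)amino, so among these compounds the drop belongs to methyl(phenyl)amino only. Nothing available explains this drop.

Still open, from the compounds shown here alone, is whether ethyl in place of the remaining methyl on this nitrogen, or a methoxy group on the phenyl, would keep the low number of compound 4.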